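Swapping the Aryl Group on the Carbonyl of Compound 2

The compounds below may be only part of what the source reports. "The series", "measured", "known", "first", "only" and "open" are said of these compounds alone.

The set comprises three measured compounds and one to be measured. Compound 1 `COc1cc(-c2cc(/C=C/C(=O)c3ccc(N)cc3)[nH]n2)cc(OC)c1OC` gives 9810 nM in a functional assay on NCI-H522 cells (Homo sapiens) for inhibition, read by sulforhodamine B assay, with a stated time of 48 h; on this read-out lower numbers stand for higher toxicity in this test and higher numbers for lower toxicity in this test. Compound 2 `COc1cc(-c2cc(/C=C/C(=O)c3ccc(Cl)c(Cl)c3)[nH]n2)cc(OC)c1OC` gives 6970 nM in this assay, and compound 3 `COc1ccc(-c2cc(/C=C/C(=O)c3cc(OC)c(OC)c(OC)c3)[nH]n2)cc1OC` gives 5390 nM. Compound 2 thus holds the second highest of the three numbers, with compound 3 nearest and compound 1 furthest, and both gaps fall within the scatter of repeated measurements.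

The unmeasured compound 4 `COc1ccc(C(=O)/C=C/c2cc(-c3cc(OC)c(OC)c(OC)c3)n[nH]2)cc1` differs from compound 2 at one place: 4-methoxyphenyl in place of 3,4-dichlorophenyl on a carbonyl carbon. Going by the values given here, the only measured step that touches the same carbonyl carbon is a 1.4-fold lower number from compound 1 to compound 2 (0.15 log units; within the scatter), which did not rise above the scatter. Nothing among the three measured compounds suggests that exchanging one aryl group for another at this position moves the number appreciably, so for compound 4 no step beyond the scatter is expected, a 1.0-fold higher number from compound 2 to compound 4 (0.00 log units; within the scatter).

Compound 4 is therefore estimated to give about 7000 nM in this assay, with a plausible range from 3500 nM to 14000 nM.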

Compound 4, concentration lethal to 50% of the cells: 6970 nM
Estimate against measurement, compound 4: 1.0-fold (0.00 log units) above, within the range that was stated.
By their numbers in this assay, from the lowest: compounds 3, 2, 4 and 1 (each within the scatter of the next).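

In this assay, the exchange of 3,4-dichlorophenyl for 4-methoxyphenyl on a carbonyl carbon shows no change at the digits printed from compound 2 to compound 4 (within the scatter), even though chlorine gives way to oxygen and the entering group counts one hydrogen-bond acceptor where the leaving group counts none. Going by these compounds alone, the second new comparison, methoxy in place of amino on an aromatic carbon, shows a 1.4-fold lower number from compound 1 to compound 4 (0.15 log units; within the scatter), so the three aryl groups now compared at this carbonyl carbon all stay within the scatter of one another, with no compound going against this. No supporting measurement is available to explain why these exchanges leave the number within the scatter.

Going by these compounds, whether a group of another kind here, such as a pyridine ring, a carboxylic acid on the phenyl ring or a longer alkyl chain, would move the number beyond the scatter remains open.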